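The compounds below may be only part of what the source reports. "The series", "measured", "known", "first", "only" and "open" are said of these compounds alone.

Compound 2, `CNC(=O)[C@H]1O[C@@H](n2cnc3c(NOC)nc(C#Cc4ccc(F)cc4)nc32)[C@H](O)[C@@H]1O`, stands in an assay on CHO cells for displacement of a labelled ligand from adenosine receptor A3 (Homo sapiens) (a higher number here means a weaker inhibitor, a lower number a stronger inhibitor), at 1.9 nM, the higher of the two numbers recorded, while its nearest neighbour compound 1, `CNC(=O)[C@H]1O[C@@H](n2cnc3c(NOC)nc(I)nc32)[C@H](O)[C@@H]1O`, gives 1.7 nM in this assay; the two lie within the scatter of each other, so no order between them can be claimed. Among the compounds with values here, the only step recorded, a 1.1-fold higher number from compound 1 to compound 2 (0.05 log units; within the scatter), concerns the iodo position and not the amide end of the sugar. Compound 3, `CCNC(=O)[C@H]1O[C@@H](n2cnc3c(NOC)nc(C#Cc4ccc(F)cc4)nc32)[C@H](O)[C@@H]1O`, carries the change (methyl in place of hydrogen on a saturated chain carbon bound to an amide-type nitrogen), that is, methylcarbamoyl to ethylcarbamoyl. Within the data shown here, no measured step touches this part of the shared core, so the expectation rests on the structural change alone. Among the measured compounds shown here, since the change is small and remote from the single recorded step, compound 3 is expected to be close to compound 2, with at most a modest weakening, a 2.1-fold higher number from compound 2 to compound 3 (0.32 log units; beyond the scatter). Compound 3 is therefore estimated at 4 nM in this assay, within a range from 1.5 nM to 12 nM.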

Compound 3, inhibition constant: 3.2 nM
Compound 3: the middle estimate sits 1.3-fold (0.10 log units) above what was measured; the measured number falls inside the stated range.
By their numbers in this assay, from the lowest: compounds 1, 2 and 3 (each within the scatter of the next).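

Within the data shown here, the step from methylcarbamoyl to ethylcarbamoyl is the first recorded at this end of the molecule. In this assay it comes to a 1.7-fold higher number from compound 2 to compound 3 (0.23 log units; within the scatter) and so shows that a methyl on a saturated chain carbon bound to an amide-type nitrogen leaves compound 3 within the scatter of compound 2, at least with the 2-(4-fluorophenyl)ethynyl group in place. No supporting data are available that could account for this result.

Going by these compounds, whether a longer chain such as propyl, a ring such as cyclopropyl, or a plain primary carboxamide would also stay within the scatter remains open, and a single step gives no trend along the chain. Also open, on these data alone, is whether ethylcarbamoyl would give a similar reading with iodo in place of the 2-(4-fluorophenyl)ethynyl group.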